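A few compounds are considered here, and "the series" means these few. Any claim that something is new, unique, unknown or untested is made for them only; others in the source may bear on it.

Compound 1, `Cc1cccc(C)c1Oc1cc(Nc2ccc(C#N)cc2)[nH]c(=O)c1Cl`, gives 29000 nM in an ADME assay on MT4 cells (Homo sapiens) for cytotoxicity, read by MTT assay, with a stated time of 5 days; a lower number here means that less compound is tolerated, a higher number that more compound is tolerated.
Compound 2, `Cc1cccc(C)c1Oc1cc(Nc2ccc(C#N)cc2)[nH]c(=O)c1`, gives 36000 nM in this assay.
Compound 3, `Cc1cc(C)c(Oc2cc(Nc3ccc([N+](=O)[O-])cc3)[nH]c(=O)c2)c(C)c1`, gives 26000 nM in this assay.

Compound 2 holds the highest of the three numbers, but its gap to compound 1 and to compound 3 both lie within the scatter, so the three measured compounds cannot be told apart in this assay. For the measured compounds named here, the single one-place step among them, a 1.2-fold higher number from compound 1 to compound 2 (0.09 log units; within the scatter), sits on the core and stays within the scatter.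

Compound 4, `Cc1cc(C#N)cc(C)c1Oc1cc(Nc2ccc(C#N)cc2)[nH]c(=O)c1`, differs from compound 2 by cyano in place of hydrogen on an aromatic carbon. Going by the values given here, no measured step touches this ring at this place; compound 3, which carries a methyl there together with a nitro group, differs from compound 2 in two places, and the two values show no separation beyond the scatter. With nothing to suggest a shift, the expected step of a 1.2-fold lower number from compound 2 to compound 4 (0.08 log units; within the scatter) is none beyond the scatter. For compound 4 the estimate in this assay is 30000 nM, within 15000 nM to 60000 nM.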

Compound 4, half-maximal cytotoxic concentration: 25000 nM
For compound 4 the middle estimate is 1.2-fold (0.08 log units) above the measured one; the measured number falls inside the stated range.
By their numbers in this assay, from the lowest: compounds 4, 3, 1 and 2 (each within the scatter of the next).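

For the compounds shown here, the step of a 1.4-fold lower number from compound 2 to compound 4 (0.16 log units; within the scatter) is the first direct reading of a change on this ring, where the earlier one-place step touched only the core. In this assay, cyano in place of hydrogen, on the aromatic carbon meta to two methyl groups and para to a large group, therefore gives no separation from the unsubstituted compound 2, and this place tolerates the added nitrile without a readable shift. No measurement at hand offers an explanation for this outcome.

Going by these compounds, whether an amine or a carboxylic acid on this same aromatic carbon would also stay within the scatter remains open, since a single group at this place gives no trend. Also open, on these data alone, is whether the cyano step would read the same with the chloro of compound 1 on the core.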